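A Smaller Tail on the Piperazine Nitrogen

The source may report more compounds than this note shows. Statements on the series, on what has been measured and on what is new or still open speak of the compounds shown alone.

Compound 1 `CCN(CC)c1ccc2cc(C(=O)c3ccc(N4CCN(C(=O)CN5CCN(C(=O)/C=C/c6ccccc6)CC5)CC4)cc3)oc2c1` was tested in an ADME assay on L02 cells (Homo sapiens) for cytotoxicity, read by MTT assay, with a stated time of 48 h; a lower number here means a stronger inhibitor, a higher number a weaker inhibitor. In this assay compound 1 reaches only a limit of the assay, > 100000 nM, not a measured number. Compound 2 `CCN(CC)c1ccc2cc(C(=O)c3ccc(N4CCN(C(=O)CN5CCN(S(=O)(=O)c6ccc(C(F)(F)F)cc6)CC5)CC4)cc3)oc2c1` gives 17000 nM in this assay. The change to compound 3 `CCN(CC)c1ccc2cc(C(=O)c3ccc(N4CCN(C(=O)CN5CCN(CC(C)=O)CC5)CC4)cc3)oc2c1` is 2-oxopropyl in place of (2-phenylethenyl)carbonyl on an amine nitrogen in a ring. Among the measured compounds shown here, no step between two measured compounds is available, so only a guess is possible; since compound 1 sits at the limit of > 100000 nM in this assay, at which 1 of the 2 values shown sits, the step of an at least 1.2-fold lower number from compound 1 to compound 3 (0.09 log units; that floor lies within the scatter) is expected to be small, with a fair chance that another limit is reported. Compound 3 is estimated at 80000 nM, between 20000 nM and 300000 nM.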

Compound 3, half-maximal inhibitory concentration: > 100000 nM
Compound 3: no number, only a limit (the forecaster's own chance of this, stated with the estimate: 60%); at least 1.2-fold (0.09 log units) between middle value and limit.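

Compound 1 and compound 3 both stop at a limit in this assay, so the step between them cannot be read. Going by these compounds, whether 2-oxopropyl and (2-phenylethenyl)carbonyl on this ring nitrogen differ at all remains open.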